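Shared-core series: 2-methylphenyl for propyl, cytotoxicity notes

The source may report more compounds than this note shows. Statements on the series, on what has been measured and on what is new or still open speak of the compounds shown alone.

Measured so far in an ADME assay on KB cells (Homo sapiens) for cytotoxicity, read by MTT assay, with a stated time of 44 h; on this read-out lower numbers stand for stronger inhibition and higher numbers for weaker inhibition:
compound 1 `CCCCNC(=S)N/N=C\c1c[nH]c2ccccc12` — a limit of the assay, > 100000 nM
compound 2 `CC(C)NC(=S)N/N=C\c1c[nH]c2ccccc12` — a limit of the assay, > 100000 nM
compound 3 `CCCNC(=S)N/N=C\c1c[nH]c2ccccc12` — a limit of the assay, > 100000 nM

Compound 3 stands at the limit of this assay, as do the two other measured compounds: the limit of > 100000 nM in this assay, at which 3 of the 3 values shown sit. The steps among them, a step that the two limits leave unreadable from compound 1 to compound 2, a step that the two limits leave unreadable from compound 1 to compound 3 and a step that the two limits leave unreadable from compound 2 to compound 3, cannot be read; all three values are limits, so no size and no direction is available from them.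

Compound 4 `Cc1ccccc1NC(=S)N/N=C\c1c[nH]c2ccccc12` differs from compound 3 by 2-methylphenyl in place of propyl on an amide-type nitrogen. Going by the values given here, no measured step bears directly on an aryl group at this nitrogen, and the three measured steps give no readable size at all. The data therefore support no expectation of a step beyond the scatter in either direction in this assay, and the expected step from compound 3 to compound 4 is a number no higher from compound 3 to compound 4 (the limit leaves the size open). Compound 4 is estimated to give 100000 nM in this assay, with a range from 30000 nM to 300000 nM, and a limit is the most likely report.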

Compound 4, half-maximal inhibitory concentration: > 100000 nM
Compound 4 gave a limit, no number; the forecaster's own chance of this, stated with the estimate: 75%; the middle value sits exactly at the limit.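

Compound 4 also returns a limit in this assay, so its steps from compound 1, compound 2 and compound 3 cannot be read: the limit of > 100000 nM in this assay, at which 4 of the 4 values shown sit.

The compounds shown leave open whether any group on this amide-type nitrogen gives a measurable value in this assay.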